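Hydroxamate series: side-chain swap at the amide nitrogen

The compounds below may be only part of what the source reports. "The series", "measured", "known", "first", "only" and "open" are said of these compounds alone.

Three compounds of this set have a number in a physicochemical assay for solubility; a lower number here means a less soluble compound, a higher number a more soluble compound. Compound 1 `CC(C)C(NC(=O)c1ccc(C#Cc2ccccc2)cc1)C(=O)NO` gives 7000 nM; compound 2 `O=C(NC1(C(=O)NO)CCC1)c1ccc(C#Cc2ccccc2)cc1` gives 5000 nM; compound 3 `O=C(NC1(C(=O)NO)CCS(=O)(=O)CC1)c1ccc(C#Cc2ccccc2)cc1` gives 2000 nM. Compound 1 thus holds the highest of the three numbers in this assay, the gap to compound 3 lying beyond the scatter and the gap to compound 2 within it.

Compound 4 `CSC[C@H](NC(=O)c1ccc(C#Cc2ccccc2)cc1)C(=O)NO` is not yet measured. It differs from compound 1 in one place: a group of 8 heavy atoms (4 carbon, 1 nitrogen, 2 oxygen, 1 sulfur; no ring) in place of a group of 8 heavy atoms (5 carbon, 1 nitrogen, 2 oxygen; no ring), on an amide-type nitrogen. The group that leaves and the group that enters match in size; the entering one carries one more acceptor and a sulfur.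

For the measured compounds named here, only one measured step touches the same position: a 1.4-fold lower number from compound 1 to compound 2 (0.15 log units; within the scatter), where a ring closure of the side chain changed little. Going by the values given here, compound 3 against compound 1 adds a sulfone-bearing ring and sits lower, but no single-change step links them to compound 4. On this basis the step is expected to stay within the scatter, with no clear direction, so compound 4 is expected to come in at 6000 nM in this assay, within 3000 nM to 12000 nM, which means an expected step of a 1.2-fold lower number from compound 1 to compound 4 (0.07 log units; within the scatter).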

Compound 4, solubility: 2000 nM
Compound 4: middle estimate off by 3.0-fold (0.48 log units), on the high side; the measured number lies below the stated range.
By their numbers in this assay, from the lowest: compounds 3 and 4 (each within the scatter of the next); then compounds 2 and 1 (each within the scatter of the next).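

Working notes on the position on the amide-type nitrogen: in this assay this position responds to a swap that keeps the heavy-atom count of the group, since the open sulfur-bearing chain gives a 3.5-fold lower number from compound 1 to compound 4 (0.54 log units; beyond the scatter) and so lies beyond the scatter, whereas the earlier step at this position (a 1.4-fold lower number from compound 1 to compound 2 (0.15 log units; within the scatter)) stayed within it. The same entering group also gives a 2.5-fold lower number from compound 2 to compound 4 (0.40 log units; beyond the scatter) against the 1-(hydroxycarbamoyl)cyclobutyl group, so the lower number appears with either leaving group. No supporting data bear on why the number falls at this position.

From the compounds shown here alone, it remains open whether the sulfur atom alone carries the step or the chain as a whole does, and whether the defined stereocentre of compound 4 plays any part. Going by these compounds, how an ether oxygen in place of the sulfur, or a primary amine at the chain end, would read at this place is equally open.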